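This account rests on a few compounds, and the source may have more. Where it says the series, first, only, none or still open, it means among the compounds named here.

Measured compounds in an assay on CHO cells with Alpha-2B adrenergic receptor (Homo sapiens) as the target; a higher number here means a larger maximal response, a lower number a smaller maximal response:
compound 1, `CCOc1ccccc1OC(C)C1=NCCN1`, gives 0.5
compound 2, `CC(C)Oc1ccccc1OC(C)C1=NCCN1`, gives 0.5

Going by the values given here, compound 1 stands level with compound 2 in this assay; the only measured step, no change at the digits printed from compound 1 to compound 2 (within the scatter), puts methyl in place of hydrogen on a saturated chain carbon bound to an oxygen on an aromatic ring and a saturated chain carbon, and it left the maximal response where it was.

The unmeasured compound 3, `CC(Oc1ccccc1Br)C1=NCCN1`, differs from compound 1 in another part of the molecule: bromo in place of ethoxy on an aromatic carbon. Among the compounds with values here, no measured step touches the group on the aromatic carbon, so the single known step bears on this change only indirectly, as a sign that compound 1 and compound 2 hold the same maximal response while a substituent is altered. On that thin ground the account expects no step beyond the scatter in this assay for compound 3, and treats the direction as open.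

Compound 3 is therefore estimated at 0.5 in this assay, with a range from 0.3 to 0.7. The expected step of no change at the digits printed from compound 1 to compound 3 (within the scatter) is small, and the measurement will tell.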

Compound 3, intrinsic activity: the largest response reached, as a fraction of the reference agonist's: 0.4
Compound 3: the middle estimate sits 0.10 above what was measured; the measured number falls inside the stated range.
By their numbers in this assay, from the lowest: compounds 3, 1 and 2 (each within the scatter of the next).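

In this assay, going by these compounds alone, the earlier compounds only exchanged ethoxy for isopropoxy, whereas compound 3 puts a single bromine atom on this aromatic carbon, ortho to a group of 8 heavy atoms, with a number 0.10 lower from compound 1 to compound 3 (within the scatter) and a number 0.10 lower from compound 2 to compound 3 (within the scatter). Both steps lie within the scatter, so across compounds 1, 2 and 3 the maximal response gives no sign of depending on whether this carbon bears ethoxy, with its 3 heavy atoms and hydrogen-bond acceptor, or bromo, which has 1 heavy atom and no acceptor. The data offer no independent measurement that could explain why the maximal response stays within the scatter through this exchange.

The compounds shown leave open whether this result holds for groups of a different kind at the same carbon, such as an amine, a carboxylic acid or a longer chain like butoxy. They also leave open whether the same exchange would stay within the scatter if the rest of the shared core were changed, since every comparison here rests on that one core.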